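This account rests on a few compounds, and the source may have more. Where it says the series, first, only, none or still open, it means among the compounds named here.

Compound 1 `CC1CCN(Cc2ccc3nc(NC(=O)N/N=C/c4cn(Cc5ccc(Cl)cc5Cl)c5ccccc45)sc3c2)CC1`, compound 2 `CC1CCN(Cc2ccc3nc(NC(=O)N/N=C/c4cn(Cc5cccc(Cl)c5)c5ccccc45)sc3c2)CC1` and compound 3 `CC1CCN(Cc2ccc3nc(NC(=O)N/N=C/c4cn(Cc5ccccc5Cl)c5ccccc45)sc3c2)CC1` share one core and differ in the chlorophenyl group on a saturated chain carbon bound to an aromatic nitrogen. In a functional assay on NCI-H460 cells (Homo sapiens) for cytotoxicity, read by MTT assay, with a stated time of 72 h (on this read-out lower numbers stand for stronger inhibition and higher numbers for weaker inhibition), compound 1 gives 1660 nM, compound 2 gives 280 nM and compound 3 gives 1080 nM. Compound 2 thus holds the lowest of the three numbers. Compound 4 `CN(C)Cc1ccc2nc(NC(=O)N/N=C/c3cn(Cc4cccc(Cl)c4)c4ccccc34)sc2c1` departs from compound 2 at a different place: dimethylamino in place of 4-methylpiperidin-1-yl on a saturated chain carbon bound to an aromatic carbon. In words, it carries dimethylamino in place of 4-methylpiperidin-1-yl on a saturated chain carbon bound to an aromatic carbon.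

Within the data shown here, none of the measured steps touches this group. All three lie at the chlorophenyl end: a 5.9-fold lower number from compound 1 to compound 2 (0.77 log units; beyond the scatter) and a 3.9-fold higher number from compound 2 to compound 3 (0.59 log units; beyond the scatter) are modest and beyond the scatter, while a 1.5-fold lower number from compound 1 to compound 3 (0.19 log units; within the scatter) stays within it. They show only what size of step these compounds have given in this assay at another place, and they offer no direction for this change. A step of modest size at most therefore seems likely, and it may not clear the scatter. Compound 2 starts from the lowest number, so a slight rise is the leaning, though the data cannot settle this. The expected result is a 1.4-fold higher number from compound 2 to compound 4 (0.15 log units; within the scatter). For compound 4 the estimated value is 400 nM, with an expected range from 130 nM to 1200 nM.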

Compound 4, half-maximal inhibitory concentration: 420 nM
Beside the measured number, compound 4's estimate is 1.1-fold (0.02 log units) below it; measured number inside the range.
By their numbers in this assay, from the lowest: compounds 2 and 4 (each within the scatter of the next); then compounds 3 and 1 (each within the scatter of the next).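

In this assay, among these compounds, this is the first change away from the chlorophenyl end, and it gives a 1.5-fold higher number from compound 2 to compound 4 (0.18 log units; within the scatter). Unlike a 5.9-fold lower number from compound 1 to compound 2 (0.77 log units; beyond the scatter) and a 3.9-fold higher number from compound 2 to compound 3 (0.59 log units; beyond the scatter), which both lie beyond the scatter, this step shows no readable effect of replacing 4-methylpiperidin-1-yl with dimethylamino on a saturated chain carbon bound to an aromatic carbon, even though the group drops from 7 heavy atoms to 3 and loses its six-membered ring, so with the 3-chlorophenyl group in place, this read-out does not depend on that ring being present. No measured evidence shown here accounts for this result.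

From the compounds shown here alone, all of this rests on a single pair, so it remains open whether the same exchange would also stay within the scatter with the 2-chlorophenyl or 2,4-dichlorophenyl group of compound 3 or compound 1 in place. The compounds shown also leave open how this read-out would respond to a morpholin-4-yl group, a carboxylic acid or a longer chain at this place, since the two amines compared here say nothing about such groups.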